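The source may hold more compounds than are shown below. What is called first, only, known or untested is meant among the compounds shown, and "the series" means these compounds.

Two compounds of the series carry numbers in an assay on isolated protein for inhibition of histone acetyltransferase p300 (Homo sapiens), with a stated time of 60 min; on this read-out higher numbers stand for weaker inhibition and lower numbers for stronger inhibition. Compound 1 `O=C(Nc1ccc2[nH]c(=O)[nH]c2c1)[C@H]1CCCN1C(=O)C1(c2cccc(Cl)c2)CCCC1` gives 0.398 nM, the lower of the two; compound 2 `COc1ccc(NC(=O)[C@H]2CCN2C(=O)C2(c3ccc(Cl)cc3)CCCC2)cc1` gives 39.8 nM, a higher number, with a gap beyond the scatter. Compound 3 `O=C(Nc1ccc2[nH]ncc2c1)[C@H]1CCCN1C(=O)C1(c2cccc(Cl)c2)CCCC1` differs from compound 1 in a single place: a group of 9 heavy atoms (7 carbon, 2 nitrogen; one five-membered aromatic ring with 2 hetero atoms, one six-membered aromatic ring of carbon only) in place of a group of 10 heavy atoms (7 carbon, 2 nitrogen, 1 oxygen; one five-membered aromatic ring with 2 hetero atoms, one six-membered aromatic ring of carbon only), on an amide-type nitrogen. Among the measured compounds shown here, no measured pair shows this change, so its size is not fixed by the data; a modest weakening is expected, the step from compound 1 to compound 3 being put at a 7.5-fold higher number from compound 1 to compound 3 (0.88 log units; beyond the scatter). Compound 3 is accordingly estimated at 3 nM, with a range from 0.6 nM to 15 nM.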

Compound 3, half-maximal inhibitory concentration: 1 nM
Compound 3: middle estimate off by 3.0-fold (0.48 log units), on the high side, within the range that was stated.
By their numbers in this assay, from the lowest: compound 1; then compound 3; then compound 2.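

Among the compounds shown here, on the amide-type nitrogen, replacing the group of compound 1 with 1H-indazol-5-yl gives a 2.5-fold higher number from compound 1 to compound 3 (0.40 log units; beyond the scatter) in this assay as the first single-place step. The change removes the oxygen, the double bond outside aromatic rings and one hydrogen-bond donor, yet the cost is modest and compound 3 still gives 1 nM. No evidence on the origin of this step is at hand. Open, as far as these compounds go, is how a plain phenyl or a pyridine ring on the same nitrogen would compare, and whether this step holds elsewhere.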